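Swapping a Cyclic Imide for Methoxy: Solubility Outlook

The compounds below may be only part of what the source reports. "The series", "measured", "known", "first", "only" and "open" are said of these compounds alone.

Compound 1 `CCN1CCN(C[C@H]2CN(c3ccc(-n4cc(-c5ccccn5)cn4)c(F)c3)C(=O)O2)CC1`: 706000 nM
Compound 2 `O=C1CCC(=O)N1C[C@H]1CN(c2ccc(-n3cc(-c4ccccn4)cn3)c(F)c2)C(=O)O1`: 45300 nM

These two compounds share one core and differ only in the group on a saturated chain carbon bound to a saturated ring carbon. Among the measured compounds shown here, in a physicochemical assay for solubility, read by HPLC, with a stated time of 24 h (on this read-out higher numbers stand for higher solubility and lower numbers for lower solubility), compound 2 stands lowest of the two numbers, and the step of a 16-fold lower number from compound 1 to compound 2 (1.19 log units; beyond the scatter) is the only measured step available. Compound 3 `COC[C@H]1CN(c2ccc(-n3cc(-c4ccccn4)cn3)c(F)c2)C(=O)O1` has not yet been measured. Its change from compound 2 is methoxy in place of 2,5-dioxopyrrolidin-1-yl on a saturated chain carbon bound to a saturated ring carbon. For the measured compounds named here, the one measured step bears on this only loosely: it shows that the group at this position can move the number a great deal, but it exchanged a different pair of groups, one of which carried a basic amine. Both the leaving group and the entering methoxy have no net charge, so for compound 3 the step of a 1.3-fold higher number from compound 2 to compound 3 (0.12 log units; within the scatter) is expected to be modest. The estimate for compound 3 is 60000 nM, with a range from 15000 nM to 200000 nM.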

Compound 3, solubility: 36200 nM
Compound 3: the middle estimate sits 1.7-fold (0.22 log units) above what was measured; measured number inside the range.
By their numbers in this assay, from the lowest: compounds 3 and 2 (each within the scatter of the next); then compound 1.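

In this assay, the exchange of 2,5-dioxopyrrolidin-1-yl (7 heavy atoms, with a ring) for methoxy (2 heavy atoms, no ring) gives a 1.3-fold lower number from compound 2 to compound 3 (0.10 log units; within the scatter) and stays within the usual scatter, so at this position these two groups cannot be told apart on this read-out. Among the compounds shown here, compound 1 stands clear of compound 3 as well, with a 20-fold lower number from compound 1 to compound 3 (1.29 log units; beyond the scatter) and a step beyond the scatter, so 4-ethylpiperazin-1-yl is the one group of the three that gives a distinct number here. Nothing measured alongside these numbers speaks to what lies behind them.

Still open, as far as these compounds go, is which part of 4-ethylpiperazin-1-yl goes with the higher number, and a simpler amine such as dimethylamino in its place would test that. From the compounds shown here alone, whether a carboxylic acid at this position would stay with compound 2 and compound 3 or move away from them also remains open.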